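Replacing bromo with cyano in a tight compound series

The source may report more compounds than this note shows. Statements on the series, on what has been measured and on what is new or still open speak of the compounds shown alone.

Of the compounds shown here, three built on a shared core have been measured in an ADME assay on L02 cells (Homo sapiens) for cytotoxicity, read by MTT assay, with a stated time of 24 h (on this read-out higher numbers stand for weaker inhibition and lower numbers for stronger inhibition), so far. Compound 1 `CN1C/C(=C\c2ccncc2)C(=O)/C(=C/c2ccccc2C(F)(F)F)C1` gives 15800 nM with methyl on the amine nitrogen in the ring. Compound 2 `O=C1/C(=C/c2ccncc2)CN(S(=O)(=O)c2ccc(Cl)cc2)C/C1=C\c1ccccc1C(F)(F)F` gives 14900 nM with (4-chlorophenyl)sulfonyl on that nitrogen, and compound 3 `O=C1/C(=C/c2ccncc2)CN(S(=O)(=O)c2ccc(Br)cc2)C/C1=C\c1ccccc1C(F)(F)F` gives 12600 nM with (4-bromophenyl)sulfonyl there. Compound 3 therefore sits within the usual scatter of both other compounds, and the numbers do not separate the three.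

Compound 4 `N#Cc1ccc(S(=O)(=O)N2C/C(=C\c3ccncc3)C(=O)/C(=C/c3ccccc3C(F)(F)F)C2)cc1` has cyano in place of bromo on an aromatic carbon, para to a large group. The counted change cyano in place of bromo on an aromatic carbon turns 4-bromophenyl into 4-cyanophenyl and leaves the rest of the molecule untouched.

The closest evidence is the swap at this same place, a 1.2-fold lower number from compound 2 to compound 3 (0.07 log units; within the scatter), where bromo replaces chloro. Replacing methyl with a larger sulfonyl group also made little difference, with a 1.1-fold lower number from compound 1 to compound 2 (0.03 log units; within the scatter) and a 1.3-fold lower number from compound 1 to compound 3 (0.10 log units; within the scatter) as the measured steps. Within the data shown here, no measured compound carries cyano, so this remains an extrapolation. All three steps lie within the scatter, so none beyond it is expected in this assay here. The expected size is a 1.1-fold higher number from compound 3 to compound 4 (0.05 log units; within the scatter) as a best guess, with no firm direction. For compound 4 the estimated value is 14000 nM, with a likely range of 7000 nM to 25000 nM around that figure.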

Compound 4, half-maximal inhibitory concentration: 17600 nM
Beside the measured number, compound 4's estimate is 1.3-fold (0.10 log units) below it; measured number inside the range.
By their numbers in this assay, from the lowest: compounds 3, 2, 1 and 4 (each within the scatter of the next).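

In this assay the swap to cyano on this aromatic carbon, which brings a triple bond and a hydrogen-bond acceptor in place of bromo, gives a 1.4-fold higher number from compound 3 to compound 4 (0.15 log units; within the scatter) and does not separate the compounds. Measured against the chloro analogue, the result is a 1.2-fold higher number from compound 2 to compound 4 (0.07 log units; within the scatter), so chloro, bromo and cyano, although they differ in their atoms, cannot be told apart at this place in this assay. Exchanging the whole (4-cyanophenyl)sulfonyl group for methyl on the ring nitrogen gives a 1.1-fold higher number from compound 1 to compound 4 (0.05 log units; within the scatter), so this third sulfonyl compound also stays within the scatter of the methyl compound, and no measurement shown offers an explanation for how closely these numbers stay together.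

Going by these compounds, it remains open whether an amine or a carboxylic acid on this aromatic carbon, or plain hydrogen there, would also stay within the scatter in this assay. The trifluoromethyl group is also the same throughout, so the compounds leave unanswered whether replacing it with chloro or methoxy would shift the number.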